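Trading Naphthalen-1-yl for Phenethyl on the Sulfur

This account rests on a few compounds, and the source may have more. Where it says the series, first, only, none or still open, it means among the compounds named here.

Going by the values given here, in a functional assay on HeLa cells (Homo sapiens) for inhibition, read by CCK-8 assay, with a stated time of 72 h, tested at 2 uM (a lower number here means less inhibition of growth, a higher number more inhibition of growth at the concentration tested), compound 3 `Nc1ccccc1NC(=O)/C=C/c1ccc(CSc2cccc3ccccc23)cc1` stands highest at 20.6% among the three numbers so far. Compound 1 `Nc1ccccc1NC(=O)/C=C/c1ccc(CSc2ccc(Cl)cc2)cc1` gives 1.94% and compound 2 `Nc1ccccc1NC(=O)/C=C/c1ccc(CSc2ccc(F)cc2)cc1` gives 7.09% under the same conditions. The unmeasured compound 4 `Nc1ccccc1NC(=O)/C=C/c1ccc(CSCCc2ccccc2)cc1` carries phenethyl in place of naphthalen-1-yl on a sulfur.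

Among the compounds with values here, two measured steps bear on this change. Putting naphthalen-1-yl in place of a substituted phenyl ring gave a number 18.7 percentage points higher from compound 1 to compound 3 (beyond the scatter) and also a number 13.5 percentage points higher from compound 2 to compound 3 (beyond the scatter) in the same direction, both modest. The swap of fluoro for chloro gave a number 5.2 percentage points higher from compound 1 to compound 2 (within the scatter) and says little here. Within the data shown here, with compound 3 at 20.6% resting on that gain, a modest fall is expected when naphthalen-1-yl leaves, though no measured compound carries phenethyl on the sulfur. In this assay the expected step is a number 11.6 percentage points lower from compound 3 to compound 4 (beyond the scatter) and remains only an estimate. For compound 4 the estimate is 9% with an expected range from 1% to 22% in this read-out.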

Compound 4, percent growth inhibition at one concentration: 0.19%
For compound 4 the middle estimate is 8.8 percentage points above the measured one; the whole stated range lies above it.
By their numbers in this assay, from the lowest: compounds 4, 1 and 2 (each within the scatter of the next); then compound 3.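

In this assay, the gain seen with naphthalen-1-yl on the sulfur does not carry over to phenethyl, which has one six-membered aromatic ring in place of two: the change gives a number 20.4 percentage points lower from compound 3 to compound 4 (beyond the scatter). Set against the substituted phenyl rings, phenethyl shows no clear shift, with a number 6.9 percentage points lower from compound 2 to compound 4 (within the scatter) and a number 1.8 percentage points lower from compound 1 to compound 4 (within the scatter), so among the four groups tested here only naphthalen-1-yl stands apart. Nothing measured here explains this difference.

Going by these compounds, it remains open whether a naphthalen-2-yl group on the sulfur would keep the gain, or whether a benzyl group or a longer chain ending in naphthalen-1-yl would hold it. All four readings also come from a single concentration, so they do not show how the compounds would compare across a range of doses.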